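The source may hold more compounds than are shown below. What is called first, only, known or untested is meant among the compounds shown, and "the series" means these compounds.

Measured in a functional assay on MCF7 cells (Homo sapiens) for inhibition; a lower number here means a stronger inhibitor, a higher number a weaker inhibitor:
- compound 1 `CCCCCCCCCCCCCCCCCCOC[C@H](COC(=O)O[C@@H]1[C@H](O)[C@@H](CO)[C@@H](O)[C@H](O)[C@@H]1O)OC`: 12500 nM
- compound 2 `CCCCCCCCCCCCCCCCCCOC[C@H](COC(=O)O[C@@H]1[C@H](O)[C@H](CO)[C@@H](O)[C@H](O)[C@@H]1O)OC`: 1200 nM

Of the two, compound 2 holds the lower number, at 1200 nM. Next is compound 3 `CCCCCCCCCCCCCCCCCCOC[C@H](COC(=O)O[C@H]1[C@@H](O)[C@@H](O)[C@H](O)C[C@H]1O)OC`, with hydrogen in place of hydroxymethyl on a saturated ring carbon. For the measured compounds named here, only one measured step bears on this, the large 10-fold lower number from compound 1 to compound 2 (1.02 log units; beyond the scatter), beyond the scatter, and there the evidence is the fact that compounds 1 and 2 differ only in the configuration as drawn. That step turns on the configuration of this same ring carbon, so the substituent there matters to this assay. Going by the values given here, no measured step removes the group, which leaves size and direction uncertain. A moderate move towards a weaker number is expected, smaller than a 10-fold lower number from compound 1 to compound 2 (1.02 log units; beyond the scatter). The estimated step is a 2.5-fold higher number from compound 2 to compound 3 (0.40 log units; beyond the scatter). The expected value for compound 3 is 3000 nM, with an estimated range of 800 nM to 12000 nM.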

Compound 3, half-maximal inhibitory concentration: 12000 nM
Compound 3: middle estimate off by 4.0-fold (0.60 log units), on the low side, within the range that was stated.
By their numbers in this assay, from the lowest: compound 2; then compounds 3 and 1 (each within the scatter of the next).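

In this assay, taking the hydroxymethyl away from the arrangement in compound 2 gives up a large step at this saturated ring carbon: a 10-fold higher number from compound 2 to compound 3 (1.00 log units; beyond the scatter). With the group in the opposite configuration, replacing it by hydrogen leaves the number within the scatter: a 1.0-fold lower number from compound 1 to compound 3 (0.02 log units; within the scatter). The hydroxymethyl therefore counts in this assay only as drawn in compound 2, while as drawn in compound 1 it reads the same as hydrogen, and this reading of the group rests on the following: the fact that compounds 1 and 2 differ only in the configuration as drawn.

From the compounds shown here alone, what a methyl, an aminomethyl or a carboxylic acid on this ring carbon would give stays open, so it is unknown whether the carbon or the hydroxy group of the hydroxymethyl carries the step. Equally open, going by these compounds, is whether a similar dependence on configuration holds at the ring atoms that bear a hydroxy group.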